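This account rests on a few compounds, and the source may have more. Where it says the series, first, only, none or still open, it means among the compounds named here.

Measured so far:
Compound 1, `Cc1ccc(-c2csc(NC(=O)COc3ccccc3C)n2)cc1`; in a functional assay on A549 cells (Homo sapiens) for cytotoxicity, read by trypan blue exclusion, with a stated time of 48 h (a higher number here means a weaker inhibitor, a lower number a stronger inhibitor), compound 1 gives 50100 nM.
Compound 2, `Cc1ccc(-c2csc(NC(=O)COc3ccccc3C(C)C)n2)cc1`; compound 2 gives 44700 nM.
Compound 3, `Cc1ccccc1OCC(=O)Nc1nc(-c2ccc(Cl)cc2)cs1`; compound 3 gives 64800 nM.

Compound 4, `CC(C)c1ccccc1OCC(=O)Nc1nc(-c2ccc(Cl)cc2)cs1`, is not yet measured. It differs from compound 3 by isopropyl in place of methyl on an aromatic carbon. The same change is already seen once, from compound 1 to compound 2, where it is isopropyl in place of methyl on an aromatic carbon and gives a 1.1-fold lower number from compound 1 to compound 2 (0.05 log units; within the scatter). The place of the change is described in the same words in both pairs, so it counts as the same change. The two cores differ by chloro in place of methyl on an aromatic carbon, with a step of a 1.3-fold higher number from compound 1 to compound 3 (0.11 log units; within the scatter). Both measured steps sit within the scatter, and compound 3 and compound 2 likewise sit within the scatter of each other. The step from compound 3 to compound 4 is therefore expected to be small, a 1.1-fold lower number from compound 3 to compound 4 (0.05 log units; within the scatter), resting on a 1.1-fold lower number from compound 1 to compound 2 (0.05 log units; within the scatter). Compound 4 is estimated at 58000 nM, with a range from 30000 nM to 115000 nM.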

Compound 4, half-maximal inhibitory concentration: 17100 nM
Estimate against measurement, compound 4: 3.4-fold (0.53 log units) above, outside the stated range (below it).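

In this assay isopropyl in place of methyl on an aromatic carbon gives a 3.8-fold lower number from compound 3 to compound 4 (0.58 log units; beyond the scatter) and so does not carry over unchanged from the core of compound 1 to the core of compound 3: the same change on two cores in this assay, a 1.1-fold lower number (0.05 log units; within the scatter) from compound 1 to compound 2 and a 3.8-fold lower number (0.58 log units; beyond the scatter) from compound 3 to compound 4, 3.4-fold (0.53 log units) apart, beyond the scatter of two such steps. Chloro in place of methyl on an aromatic carbon likewise depends on the group on the other ring, with a 2.6-fold lower number from compound 2 to compound 4 (0.42 log units; beyond the scatter) on the isopropyl side: the same change on two cores in this assay, a 1.3-fold higher number (0.11 log units; within the scatter) from compound 1 to compound 3 and a 2.6-fold lower number (0.42 log units; beyond the scatter) from compound 2 to compound 4, 3.4-fold (0.53 log units) apart, beyond the scatter of two such steps. This shows that the two changes do not add up independently in these four compounds, but it rests on a single pair of steps for each change and gives neither a cause nor a rule for other cores.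

Still open, going by these compounds, is whether the larger isopropyl step persists with fluoro or methoxy in place of chloro. Also open, on these data alone, is whether an ethyl or tert-butyl group in place of isopropyl follows the same course.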